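The compounds below may be only part of what the source reports. "The series", "measured", "known", "first", "only" and "open" are said of these compounds alone.

In an ADME assay on Vero cells (Chlorocebus sabaeus) for cytotoxicity, read by MTT assay, with a stated time of 48 h (on this read-out lower numbers stand for stronger inhibition and higher numbers for weaker inhibition), compound 1 `O=C(OC1CCC(CN2CCN(c3cc(=O)c4cc(C(F)(F)F)cc([N+](=O)[O-])c4s3)CC2)CC1)c1ccco1` gives only a limit, > 64 ug/mL. Compound 2 `COc1ccc(C(=O)OC2CCC(CN3CCN(c4cc(=O)c5cc(C(F)(F)F)cc([N+](=O)[O-])c5s4)CC3)CC2)cc1` likewise reaches only the limit, > 64 ug/mL. Compound 3 `O=c1cc(N2CCN(CC3CCC(OS(=O)(=O)c4ccc5ccccc5c4)CC3)CC2)sc2c([N+](=O)[O-])cc(C(F)(F)F)cc12` also stops at the limit, > 64 ug/mL. Within the data shown here, the single measured step, a step that the two limits leave unreadable from compound 1 to compound 2, is therefore unreadable, and compound 2 stands where every value shown stands, at the limit described by the limit of > 64 ug/mL in this assay, at which 3 of the 3 values shown sit. Compound 4 `CC(C)C(=O)OC1CCC(CN2CCN(c3cc(=O)c4cc(C(F)(F)F)cc([N+](=O)[O-])c4s3)CC2)CC1` differs from compound 2 by isopropyl in place of 4-methoxyphenyl on a carbonyl carbon. No readable measured step bears on this change, so no shift beyond the usual scatter is expected, and a limit is again the most likely outcome. For compound 4 in this assay a value of 100 ug/mL is estimated, expected to lie between 50 ug/mL and 200 ug/mL. This corresponds to an expected step that the limit leaves unreadable from compound 2 to compound 4.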

Compound 4, half-maximal inhibitory concentration: > 64 ug/mL
Compound 4: a limit, no number; the forecaster's own chance of this, stated with the estimate: 85%; the middle value does not contradict the limit.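

In this assay compound 4 gives only a limit, > 64 ug/mL. Among these compounds, no step linking compound 4 with compound 1 or compound 2 can be read. The compounds shown leave open whether any group on the carbonyl carbon changes cytotoxicity in this assay.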